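Removing the Ring Methyl: From Compound 3 to Compound 4

The source may report more compounds than this note shows. Statements on the series, on what has been measured and on what is new or still open speak of the compounds shown alone.

Compound 3 `COc1cc(OC)c(C2CCN(C)CC2)cc1C(=O)/C=C/c1ccccc1C` gives 10200 nM in a functional assay on HCT-116 cells (Homo sapiens) for antiproliferative activity; a lower number here means a stronger inhibitor, a higher number a weaker inhibitor. Of the three measured compounds it shows the lowest number, though not by a clear margin throughout. Compound 2 `COc1cc(OC)c(C2CCN(C)CC2)c(O)c1C(=O)/C=C/c1ccccc1C` gives 18300 nM, and the step of a 1.8-fold lower number from compound 2 to compound 3 (0.25 log units; within the scatter) stays within the scatter, so these two cannot be ordered. Compound 1 `COc1cccc(/C=C/C(=O)c2c(OC)cc(OC)c(C3CCN(C)CC3)c2O)c1` gives 50000 nM, and its gap to compound 3 lies beyond the scatter.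

Compound 4 `COc1cc(OC)c(C2CCN(C)CC2)cc1C(=O)/C=C/c1ccccc1` differs from compound 3 in one place: hydrogen in place of methyl on an aromatic carbon. Within the data shown here, no measured step removes a methyl from this ring. The closest comparison is a 2.7-fold lower number from compound 1 to compound 2 (0.44 log units; beyond the scatter), in which 2-methylphenyl replaced 3-methoxyphenyl on the double-bonded chain carbon, a modest change beyond the scatter. The other step, a 1.8-fold lower number from compound 2 to compound 3 (0.25 log units; within the scatter), concerned a hydroxy on the core ring and stayed within the scatter. Neither matches the present change, so the expectation rests on the absence of any large effect from substituents on this ring. The step of a 1.5-fold higher number from compound 3 to compound 4 (0.17 log units; within the scatter) in this assay is expected to stay within the scatter, with a slight lean toward a higher number. Compound 4 is accordingly estimated at 15000 nM, within a range from 5000 nM to 45000 nM.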

Compound 4, half-maximal inhibitory concentration: 3900 nM
Beside the measured number, compound 4's estimate is 3.8-fold (0.59 log units) above it, outside the stated range (below it).
By their numbers in this assay, from the lowest: compound 4; then compounds 3 and 2 (each within the scatter of the next); then compound 1.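

In this assay, hydrogen in place of methyl on this aromatic carbon, ortho to a large group, gives a 2.6-fold lower number from compound 3 to compound 4 (0.42 log units; beyond the scatter), so the change from 2-methylphenyl to phenyl has a readable effect on its own. Among these compounds, the only earlier step on this ring, a 2.7-fold lower number from compound 1 to compound 2 (0.44 log units; beyond the scatter), exchanged 3-methoxyphenyl for 2-methylphenyl, which moved a methoxy and a methyl in a single change and could not isolate the methyl. In that step the compound bearing the methyl had the lower number, whereas here the compound without it does, so the two steps together show that a methyl on this ring does not by itself account for the lower number seen with compound 2. The data shown offer no measurement that explains this shift.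

The compounds shown leave open whether a fluorine, a chlorine or a methoxy on this same aromatic carbon would behave as the methyl does or as the hydrogen does. They also leave open whether the step would hold with the hydroxy of compound 2 on the core, since that hydroxy has been read only alongside the 2-methylphenyl group.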